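Thienopyrimidine styryl series: amine swap on compound 3

The compounds below may be only part of what the source reports. "The series", "measured", "known", "first", "only" and "open" are said of these compounds alone.

Measured so far in a functional assay on L02 cells (Homo sapiens) for inhibition, read by Griess assay, with stated times of 1 h and 24 h; a higher number here means a weaker inhibitor, a lower number a stronger inhibitor:
- compound 1, `CCCc1nn(C)c2c(NC3CC3)nc(/C=C/c3nc(C)c(C)nc3C)nc12`: compound 1 gives 706000 nM
- compound 2, `Clc1ccccc1CNc1nc(/C=C/c2ccccc2)nc2ccsc12`: compound 2 reaches only a limit, > 1000000 nM
- compound 3, `COc1cc(/C=C/c2nc(Nc3ccc(C)cc3)c3sccc3n2)cc(OC)c1OC`: compound 3 reaches only a limit, < 40000 nM

Compound 3 stands at the strong end of what has been seen. Its value is a limit of this assay and not a number, as the limit of < 40000 nM in this assay, at which 1 of the 3 values shown sits, records, so its true potency is open downward. Compound 2 sits at the other limit, (the limit of > 1000000 nM in this assay, at which 1 of the 3 values shown sits), and compound 1 gives an ordinary number between the two.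

Within the data shown here, no pair of measured compounds differs in a single place, so no measured step is available. Compound 4, `COc1cc(/C=C/c2nc(NCc3ccc(Cl)cc3)c3sccc3n2)cc(OC)c1OC`, is drawn from compound 3 by 4-chlorobenzyl in place of 4-methylphenyl on a nitrogen on an aromatic ring. Compound 2, which also carries a benzyl on that nitrogen together with a styryl group on the same core, gives > 1000000 nM, a limit of this assay; this is the only hint about a benzyl at that position and it points toward weaker inhibition.

Compound 4 is therefore expected to lose potency, with a step of an at least 3.7-fold higher number from compound 3 to compound 4 (0.57 log units; beyond the scatter) judged beyond the scatter, though the limit on compound 3 makes its size uncertain. The estimate for compound 4 in this assay is 150000 nM, within 30000 nM to 800000 nM.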

Compound 4, half-maximal inhibitory concentration: > 1000000 nM
Compound 4 ended at the assay's limit; the forecaster's own chance of this, stated with the estimate: 25%; middle value at least 6.6-fold (0.82 log units) away from the limit.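

Among these compounds, the change from (4-methylphenyl)amino to (4-chlorobenzyl)amino gives the first step that differs in one place, and in this assay it reads as an at least 25-fold higher number from compound 3 to compound 4 (1.39 log units; beyond the scatter) and so marks this nitrogen substituent as a position where a single change moves the read-out by a large step, with the printed size only a lower bound. Compound 3 carries a limit of the assay and not a number (< 40000 nM) in this comparison. Compound 4 also carries a limit of the assay and not a number (> 1000000 nM) in this comparison.

The change alters two things at once, the link between the nitrogen and the aromatic ring and the substituent on that ring, and the compounds shown do not tell which of them carries the step; a 4-chlorophenyl or a 4-methylbenzyl group on that nitrogen would separate the two. Also open, going by these compounds, is how far compound 3 lies beyond its limit, and whether a morpholine or a simple hydroxyethyl amine at this place would stay on the strong side of the assay range.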